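Adding a Methyl Group to Compound 1: Expected Activity

A few compounds are considered here, and "the series" means these few. Any claim that something is new, unique, unknown or untested is made for them only; others in the source may bear on it.

Compound 1 `COC(=O)Cn1nc2c(n1)C(=O)C(C)=C(C)C2=O` and compound 2 `CC1=C(C)C(=O)c2nn(Cc3ccccc3)nc2C1=O` share one core. Among the measured compounds shown here, in a functional assay on HeLa cells (Homo sapiens) for inhibition, read by colorimetric assay, with a stated time of 72 h (on this read-out lower numbers stand for an effect already at smaller amounts and higher numbers for an effect only at larger amounts of compound), compound 1 gives 1 ug/mL, the highest of the two numbers known, while compound 2 gives 0.8 ug/mL; the step between them is a 1.3-fold lower number from compound 1 to compound 2 (0.10 log units; within the scatter). Compound 3 `COC(=O)C(C)n1nc2c(n1)C(=O)C(C)=C(C)C2=O` differs from compound 1 by methyl in place of hydrogen on a saturated chain carbon bound to an aromatic nitrogen and a carbonyl carbon. For the measured compounds named here, no measured step swaps hydrogen for methyl at that place; the only known step changes a different group and stays within the scatter. Compound 3 is therefore expected to shift by no more than the scatter, no change at the digits printed from compound 1 to compound 3 (within the scatter). The estimate for compound 3 in this assay is 1 ug/mL, ranging from 0.4 ug/mL to 2.5 ug/mL.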

Compound 3, concentration for half-maximal effect: 0.9 ug/mL
Compound 3: the middle estimate sits 1.1-fold (0.05 log units) above what was measured; the measured number falls inside the stated range.
By their numbers in this assay, from the lowest: compounds 2, 3 and 1 (each within the scatter of the next).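

In this assay methyl in place of hydrogen on a saturated chain carbon bound to an aromatic nitrogen and a carbonyl carbon gives a 1.1-fold lower number from compound 1 to compound 3 (0.05 log units; within the scatter) and so shows that this position accepts one added carbon with the numbers staying within the scatter. The earlier step replaced the methoxycarbonyl group, whereas this one keeps that group and alters the chain carbon itself. No measured evidence accounts for this result.

On these data alone, whether larger groups at this carbon, such as isopropyl, or an amine would also stay within the scatter remains open. So does the effect of a carboxylic acid in place of the methyl ester.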